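Cyanoguanidine Minimum Effective Dose: Sec-Butyl Versus 2-Ethoxyethyl

This account rests on a few compounds, and the source may have more. Where it says the series, first, only, none or still open, it means among the compounds named here.

Compound 1 `CCC(C)/N=C(\NC#N)Nc1cccnc1`: 20 mg/kg
Compound 2 `CC(C)C(/N=C(\NC#N)Nc1cccnc1)C(C)C`: 5 mg/kg

In a functional assay on the whole organism (blood, strain Wistar-Okamoto) with Rattus norvegicus as the target, with a stated time of 5 days (a higher number here means that more compound is needed for the effect, a lower number that less compound is needed), compound 1 gives 20 mg/kg, the highest of the two numbers measured. Its nearest neighbour, compound 2, gives 5 mg/kg in this assay, a gap that lies beyond the usual scatter. Compound 3 `CCOCC/N=C(\NC#N)Nc1cccnc1` has not yet been measured. It differs from compound 1 in one place: 2-ethoxyethyl in place of sec-butyl on a double-bonded nitrogen. Among the measured compounds shown here, no step between two measured compounds covers this kind of exchange, so nothing measured here shows how this change affects the minimum effective dose. Compound 3 is therefore expected to stay close to compound 1, with the step of a 1.3-fold higher number from compound 1 to compound 3 (0.10 log units; within the scatter) expected to fall within the scatter and in no clear direction. The estimate for compound 3 in this assay is 25 mg/kg, with a range from 8 mg/kg to 60 mg/kg.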

Compound 3, minimum effective dose: > 20 mg/kg
Compound 3: only a limit was reported; the forecaster's own chance of this, stated with the estimate: 10%; the middle value does not contradict the limit.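

In this assay compound 3 gives > 20 mg/kg as a limit of the assay and not as a number. The exchange of sec-butyl for 2-ethoxyethyl on a double-bonded nitrogen now has a measured outcome, which reads as a number no lower from compound 1 to compound 3 (the limit leaves the size open) for this change. It gives no sign that 2-ethoxyethyl lowers the dose needed, but how far the number moves cannot be read, and the reading rests on a single limit: the limit of > 20 mg/kg in this assay, at which 1 of the 3 values shown sits.

The compounds shown leave open whether the result belongs to the oxygen of 2-ethoxyethyl or to the chain that carries it. A pentyl chain on the same nitrogen, made of carbon alone, would separate these two readings.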